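The compounds below may be only part of what the source reports. "The series", "measured", "known", "first", "only" and "open" are said of these compounds alone.

Measured so far in a functional assay (aorta) with Oryctolagus cuniculus as the target; on this read-out lower numbers stand for tighter binding and higher numbers for weaker binding:
compound 1, `COc1cc(C(C)=O)ccc1OCCCN1CCC(C(c2ccc(F)cc2)c2ccc(F)cc2)CC1`: 1.59 nM
compound 2, `COc1cc(C(C)=O)ccc1OCCCN1CCC(C(c2ccccc2)c2ccc(F)cc2)CC1`: 6.31 nM
compound 3, `COc1cc(C(C)=O)ccc1OCCCN1CCC(C(c2ccc(F)cc2)c2ccccn2)CC1`: 158 nM

Compound 1 stands lowest of the three numbers in this assay. Its nearest neighbour is compound 2, a 4.0-fold higher number from compound 1 to compound 2 (0.60 log units; beyond the scatter); the furthest is compound 3, a 99-fold higher number from compound 1 to compound 3 (2.00 log units; beyond the scatter). Between the other two, a 25-fold higher number from compound 2 to compound 3 (1.40 log units; beyond the scatter). All three measured steps alter the two aromatic rings on the saturated chain carbon of the shared core and leave the aryloxy end untouched.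

Compound 4, `Fc1ccc(C(c2ccc(F)cc2)C2CCN(CCCOc3ccc(Br)cc3)CC2)cc1`, changes that untouched end: 4-bromophenyl in place of 4-acetyl-2-methoxyphenyl on an oxygen on a saturated carbon. Going by the values given here, no measured step bears on this position, so the change has no direct precedent; the steps seen elsewhere in the core run from modest to large. Given the absence of a comparable step, the expectation rests on compound 1 alone, and a moderate weakening is estimated, a 3.8-fold higher number from compound 1 to compound 4 (0.58 log units; beyond the scatter). Compound 4 is therefore expected at about 6 nM, in the range 1.5 nM to 40 nM.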

Compound 4, dissociation constant: 1.59 nM
For compound 4 the middle estimate is 3.8-fold (0.58 log units) above the measured one; measured number inside the range.
By their numbers in this assay, from the lowest: compounds 1 and 4 (each within the scatter of the next); then compound 2; then compound 3.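

In this assay, the aryloxy end shows a result that the earlier ring steps could not: 4-bromophenyl in place of 4-acetyl-2-methoxyphenyl on an oxygen on a saturated carbon gives no change at the digits printed from compound 1 to compound 4 (within the scatter). The hydrogen-bond acceptors counted on 4-acetyl-2-methoxyphenyl are absent from 4-bromophenyl, so within this pair they are not required to keep the number low, whereas a single ring change at the other end gives a 99-fold higher number from compound 1 to compound 3 (2.00 log units; beyond the scatter). No measurement available here accounts for this result.

On these data alone, the acetyl, the methoxy and the bromine differ together in this single pair, so their separate contributions, including any offset between them, stay open. Also open, as far as these compounds go, is whether this end accepts a very different group, such as a carboxylic acid or an amine on the phenyl ring.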